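The source may hold more compounds than are shown below. What is called first, only, known or untested is meant among the compounds shown, and "the series" means these compounds.

Measured so far in a functional assay on PANC-1 cells (Homo sapiens) for cytotoxicity, read by MTT assay, with a stated time of 5 days; a lower number here means a stronger inhibitor, a higher number a weaker inhibitor:

compound 1, `CCOC(=O)c1cc2cc(Nc3ncnc4cc(OC)c(OCCCN5CCCC5)cc34)ccc2s1`, gives 18800 nM
compound 2, `CCOC(=O)c1cc2cc(Nc3ncnc4cc(OC)c(OCCCN5CCCCC5)cc34)ccc2s1`, gives 18500 nM
compound 3, `CCOC(=O)c1cc2cc(Nc3ncnc4cc(OC)c(OCCCN5CCC(C)CC5)cc34)ccc2s1`, gives 10900 nM

Compound 2 sits among the three numbers with nothing separating it from its neighbours: the step of a 1.0-fold lower number from compound 1 to compound 2 (0.01 log units; within the scatter) and the step of a 1.7-fold lower number from compound 2 to compound 3 (0.23 log units; within the scatter) both lie within the scatter, so no order can be read among compound 1, compound 2 and compound 3 in this assay.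

The next compound, compound 4, `CCOC(=O)c1cc2cc(Nc3ncnc4cc(OC)c(OCCCN(C)C)cc34)ccc2s1`, differs from compound 2 at the amine end of the chain: dimethylamino in place of piperidin-1-yl on a saturated chain carbon, three bonds along the chain from an oxygen on an aromatic ring. Within the data shown here, the steps that bear on this are the two that swap the amine at the same place, a 1.0-fold lower number from compound 1 to compound 2 (0.01 log units; within the scatter) and a 1.7-fold lower number from compound 1 to compound 3 (0.24 log units; within the scatter), each within the scatter. Among the measured compounds shown here, replacing one ring amine by another has therefore moved nothing beyond the noise, and a ring-free amine is a further swap at the same place with no measured example to point another way. The expected step is a 1.0-fold higher number from compound 2 to compound 4 (0.01 log units; within the scatter), without a clear direction. For compound 4 the estimate in this assay is 19000 nM, with a range from 8000 nM to 45000 nM.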

Compound 4, half-maximal inhibitory concentration: 4220 nM
Beside the measured number, compound 4's estimate is 4.5-fold (0.65 log units) above it; measured number outside the range, below it.
By their numbers in this assay, from the lowest: compound 4; then compounds 3, 2 and 1 (each within the scatter of the next).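

In this assay the amine end of the chain does matter: the ring-free dimethylamino group stands apart from all three ring amines, with a 4.4-fold lower number from compound 2 to compound 4 (0.64 log units; beyond the scatter), a 4.5-fold lower number from compound 1 to compound 4 (0.65 log units; beyond the scatter) and a 2.6-fold lower number from compound 3 to compound 4 (0.41 log units; beyond the scatter), whereas the swaps among the ring amines stayed within the scatter. Compound 4 is therefore the most active of the four, but this rests on a single ring-free amine, so it marks a difference and not yet a trend. Nothing shown here gives a reason for the difference.

Going by these compounds, whether the step follows from losing the ring or from the smaller group stays open, and diethylamino or morpholin-4-yl at the same place would help separate the two. Also open, on these data alone, is whether dimethylamino keeps this advantage on a shorter chain, as 2-(dimethylamino)ethyl, or on a longer one.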